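A few compounds are considered here, and "the series" means these few. Any claim that something is new, unique, unknown or untested is made for them only; others in the source may bear on it.

Compound 1, with the structure `COc1cc(CNc2nc3c(N)ncnc3n2[C@@H]2O[C@H](CO)[C@@H](O)[C@H]2O)ccc1-c1ccccc1`, compound 2, with the structure `CCOc1cc(CNc2nc3c(N)ncnc3n2[C@@H]2O[C@H](CO)[C@@H](O)[C@H]2O)ccc1-c1ccccc1`, and compound 3, with the structure `NC(=O)COc1cc(CNc2nc3c(N)ncnc3n2[C@@H]2O[C@H](CO)[C@@H](O)[C@H]2O)ccc1-c1ccccc1`, share one core and differ only in the group on a saturated chain carbon bound to an oxygen on an aromatic ring. In an assay on COS-7 cells for inhibition of sodium/nucleoside cotransporter 2 (Homo sapiens), read by scintillation counting (a higher number here means a weaker inhibitor, a lower number a stronger inhibitor), compound 1 gives 1300 nM, compound 2 gives 2300 nM, and compound 3 gives 5500 nM. Compound 3 thus carries the highest number of the three: the step of a 4.2-fold higher number from compound 1 to compound 3 (0.63 log units; beyond the scatter) and the step of a 2.4-fold higher number from compound 2 to compound 3 (0.38 log units; beyond the scatter) both go beyond the scatter, whereas the step of a 1.8-fold higher number from compound 1 to compound 2 (0.25 log units; within the scatter) stays within it.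

Compound 4, with the structure `Nc1ncnc2c1nc(NCc1ccc(-c3ccccc3)c(OCCO)c1)n2[C@@H]1O[C@H](CO)[C@@H](O)[C@H]1O`, is the next step from compound 3. The change is hydroxymethyl in place of carbamoyl on a saturated chain carbon bound to an oxygen on an aromatic ring, so the carbamoylmethoxy chain becomes a 2-hydroxyethoxy chain. The two measured steps that bear on it are those leading into the carbamoyl group from compound 1 and compound 2, both of which raised the number. Taking the carbamoyl away again is therefore expected to lower the number in this assay by a modest amount, the step of a 1.6-fold lower number from compound 3 to compound 4 (0.20 log units; within the scatter), though it may not clear the scatter. Compound 4 is estimated at 3500 nM, within a range from 1500 nM to 8000 nM.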

Compound 4, half-maximal inhibitory concentration: 3100 nM
The estimate for compound 4 lay 1.1-fold (0.05 log units) above the measured number; measured number inside the range.
By their numbers in this assay, from the lowest: compounds 1, 2, 4 and 3 (each within the scatter of the next, the first and the last beyond it).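

In this assay, putting hydroxymethyl in place of carbamoyl gives a 1.8-fold lower number from compound 3 to compound 4 (0.25 log units; within the scatter), so at this position the two chain ends cannot be told apart. Adding a hydroxy to the ethoxy chain likewise gives a 1.3-fold higher number from compound 2 to compound 4 (0.13 log units; within the scatter), whereas putting hydroxymethyl in place of hydrogen on the methoxy group gives a 2.4-fold higher number from compound 1 to compound 4 (0.38 log units; beyond the scatter), the only new step that clears the scatter. Compound 4 thus lies within the scatter of both compound 2 and compound 3, even though those two lie beyond the scatter of each other, so the 2-hydroxyethoxy chain falls in the overlap and the numbers for these chains form a narrow band rather than separate levels.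

Nothing given here accounts for these numbers, so the data offer no explanation of why the hydroxy and carbamoyl chain ends read so much alike. Still open is how the number would respond to a chain ending in an amine or a carboxylic acid, or to a longer chain carrying its hydroxy further out, since every group shown stays within a narrow range.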